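Adding a methyl to the ring nitrogen chain of an oxime ester

This account rests on a few compounds, and the source may have more. Where it says the series, first, only, none or still open, it means among the compounds named here.

Measured compounds:
compound 1, `COc1cc(C(OC(C)=O)c2ccc3c(ccn3C)c2)cc(OC)c1OC`: 240 nM in a functional assay on HL-60 cells (Homo sapiens) for cytotoxicity, read by XTT assay, with a stated time of 72 h; on this read-out higher numbers stand for weaker inhibition and lower numbers for stronger inhibition
compound 2, `CCn1ccc2cc(C(OC(C)=O)c3cc(OC)c(OC)c(OC)c3)ccc21`: a limit, > 10000 nM
compound 3, `COc1cc(/C(=N/OC(C)=O)c2ccc3c(ccn3C)c2)cc(OC)c1OC`: a limit, > 10000 nM

All three were tested in this assay. Compound 1 gives a number, 240 nM. Compound 2 reaches only a limit of the assay, > 10000 nM. Compound 3 likewise reaches only a limit, > 10000 nM; two of the three values sit at the limit of > 10000 nM in this assay, at which 2 of the 3 values shown sit. Compound 1 and compound 3 differ in more than one place, and the difference between these two cores is not broken down here.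

Going by the values given here, the one counted step is from compound 1 to compound 2: methyl in place of hydrogen on a saturated chain carbon bound to an aromatic nitrogen. It produced an at least 41-fold higher number from compound 1 to compound 2 (1.61 log units; beyond the scatter), a loss of activity that carries compound 2 to the limit.

Compound 4, `CCn1ccc2cc(/C(=N\OC(C)=O)c3cc(OC)c(OC)c(OC)c3)ccc21`, has not yet been measured. It stands to compound 3 exactly as compound 2 stands to compound 1: methyl in place of hydrogen on a saturated chain carbon bound to an aromatic nitrogen. The place line is the same word for word, so it is the same change. Compound 3 already sits at a limit, and the earlier step from compound 1 to compound 2 lost activity, so no recovery is expected.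

Compound 4 is therefore expected to give 30000 nM in this assay, most likely reported only as a limit. The step from compound 3 to compound 4 is estimated as a step that the limit leaves unreadable from compound 3 to compound 4, resting on compound 3 at > 10000 nM and on an at least 41-fold higher number from compound 1 to compound 2 (1.61 log units; beyond the scatter).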

Compound 4, half-maximal inhibitory concentration: > 1000 nM
Compound 4: no number, only a limit; the forecaster's own chance of this, stated with the estimate: 90%; the middle value does not contradict the limit.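

In this assay compound 4 gives only a limit, > 1000 nM. Compound 3 also gives only a limit, > 10000 nM. Neither value is a number, so the step between compound 3 and compound 4 cannot be read. The compounds shown leave open how active compound 3 and compound 4 really are, and whether the added methyl costs activity in this pair as it does between compound 1 and compound 2.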